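Compound 3: acetamido in place of methoxy

The source may hold more compounds than are shown below. What is called first, only, known or untested is meant among the compounds shown, and "the series" means these compounds.

For the measured compounds named here, in a functional assay on A549 cells (Homo sapiens) for cytotoxicity, read by MTT assay, with a stated time of 72 h (a higher number here means a weaker inhibitor, a lower number a stronger inhibitor), compound 1 (`COc1ccc(-c2ccnc(Nc3cccc(C(N)=O)c3)n2)cc1`) gives 6700 nM as the higher of the two numbers so far. Compound 2 (`COc1ccc(-c2ccnc(Nc3cccc(NS(C)(=O)=O)c3)n2)cc1`) gives 200 nM as the other. Compound 3 (`CC(=O)Nc1ccc(-c2ccnc(Nc3cccc(C(N)=O)c3)n2)cc1`) has acetamido in place of methoxy on an aromatic carbon, para to a large group (acetamido in place of methoxy on an aromatic carbon). Going by the values given here, the only measured step is a 34-fold lower number from compound 1 to compound 2 (1.53 log units; beyond the scatter) and it is large, but it puts methanesulfonamido in place of carbamoyl, and compound 3 keeps the carbamoyl. Among the compounds with values here, that step therefore gives no direct size for this change, and no step at the methoxy has been measured. No shift beyond the scatter is expected in this assay as the working assumption, with no firm direction. The expected step is a 1.3-fold lower number from compound 1 to compound 3 (0.13 log units; within the scatter) on this estimate. For compound 3 the estimate is 5000 nM within an expected range of 1500 nM to 16000 nM for now.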

Compound 3, half-maximal inhibitory concentration: 33000 nM
Beside the measured number, compound 3's estimate is 6.6-fold (0.82 log units) below it, and the stated range ends below it.
By their numbers in this assay, from the lowest: compound 2; then compound 1; then compound 3.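

In this assay the methoxy position proves sensitive: acetamido in place of methoxy, on an aromatic carbon para to a large group, gives a 4.9-fold higher number from compound 1 to compound 3 (0.69 log units; beyond the scatter) and so lies beyond the scatter. For the compounds shown here, until now the only measured step replaced carbamoyl, so this result adds a second place where a single change moves the number, here upward with the carbamoyl kept. Nothing available bears on why the larger acetamido, with its hydrogen-bond donor, gives the higher number.

A single replacement cannot separate the effect of the added heavy atoms from that of the donor, so a plain amine or a hydroxyl on this carbon would be informative. On these data alone, it also remains open whether the step would keep its direction and size with methanesulfonamido in place of carbamoyl.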